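Bromo to chloro on a bromo(dichloro)methyl sulfone

This account rests on a few compounds, and the source may have more. Where it says the series, first, only, none or still open, it means among the compounds named here.

Compound 1 `O=[N+]([O-])c1cc(S(=O)(=O)C(Cl)(Cl)Br)ccc1NC1CCCCC1` gives 4000 nM in an assay on cells for inhibition of serine/threonine-protein kinase WNK1 (Homo sapiens), read by luminescence and Kinase-Glo, with a stated time of 2 h; on this read-out lower numbers stand for stronger inhibition and higher numbers for weaker inhibition.
Compound 2 `O=[N+]([O-])c1cc(S(=O)(=O)C(Cl)(Cl)Br)ccc1NCc1ccco1` gives 15000 nM in this assay.
Compound 3 `O=S(=O)(c1ccc(NC2CCCCC2)cc1)C(Cl)(Cl)Br` reaches only the assay limit of > 1000000 nM in this assay.

Among the numbers shown, compound 1 stands lowest; the nearest is compound 2, reached by a 3.8-fold higher number from compound 1 to compound 2 (0.57 log units; beyond the scatter), a modest step. Compound 3 sits at the limit (the limit of > 1000000 nM in this assay, at which 1 of the 3 values shown sits), and the step of an at least 250-fold higher number from compound 1 to compound 3 (2.39 log units; beyond the scatter) is large. Compound 4 `O=[N+]([O-])c1cc(S(=O)(=O)C(Cl)(Cl)Cl)ccc1NC1CCCCC1` differs from compound 1 by chloro in place of bromo on a saturated chain carbon bound to two chlorine atoms and a sulfonyl sulfur. Neither measured step touches this part of the molecule: one concerns the group on the nitrogen, the other the nitro group, and both keep the (bromo(dichloro)methyl)sulfonyl group unchanged. Among the measured compounds shown here, the data therefore hold no step that bears directly on the change from compound 1 to compound 4, and a swap of one halogen for another on that carbon is expected to give a step in this assay of no more than the usual scatter, in either direction. Compound 4 is thus expected to give about 5000 nM, between 1500 nM and 16000 nM, which corresponds to an expected 1.3-fold higher number from compound 1 to compound 4 (0.10 log units; within the scatter).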

Compound 4, half-maximal inhibitory concentration: > 1000000 nM
Compound 4 was reported as a limit; the forecaster's own chance of this, stated with the estimate: 5%; middle value at least 200-fold (2.30 log units) away from the limit.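

Until now, the steps had concerned only the group on the nitrogen and the nitro group, and the bromo(dichloro)methyl group had stayed unchanged throughout. This change shows that the position is highly sensitive to the halogen: chloro in place of bromo on a saturated chain carbon bound to two chlorine atoms and a sulfonyl sulfur gives an at least 250-fold higher number from compound 1 to compound 4 (2.39 log units; beyond the scatter), so one halogen cannot stand in for the other here in compound 1. The result for compound 4 is a limit of the assay, not a number, and it is the second compound to end there: the limit of > 1000000 nM in this assay, at which 2 of the 4 values shown sit.

The compounds shown leave open how far compound 4 lies past that limit, and whether iodo or a tribromomethyl group on the sulfonyl sulfur would fare like bromo or like chloro. They also leave open whether the same swap has a comparable effect with (furan-2-yl)methyl on the nitrogen, as in compound 2.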